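Fluorine Added to the Carboxyphenyl Ring of Compound 2

This account rests on a few compounds, and the source may have more. Where it says the series, first, only, none or still open, it means among the compounds named here.

Measured so far:
Compound 1, `CC(C)CC1(O)CCN(C(=O)Nc2cc(Oc3ccc(F)cc3)cc(Oc3ccc(C4(C(=O)O)CC4)cc3)c2)CC1`: 320 ng.h/mL
Compound 2, `CC(C)CC1(O)CCN(C(=O)Nc2cc(Oc3ccc(F)cc3)cc(Oc3ccc(C(=O)O)cc3)c2)CC1`: 70 ng.h/mL

In an ADME assay on the whole organism for pharmacokinetics, with Rattus norvegicus as the target, with a stated time of 24 h, at a dose of 1 mg/kg by the oral route (a lower number here means less compound in the circulation, a higher number more compound in the circulation at the dose given), compound 2 gives the lowest of the two numbers; its nearest neighbour is compound 1, and the step of a 4.6-fold lower number from compound 1 to compound 2 (0.66 log units; beyond the scatter) describes the change between them. Compound 3, `CC(C)CC1(O)CCN(C(=O)Nc2cc(Oc3ccc(F)cc3)cc(Oc3ccc(C(=O)O)cc3F)c2)CC1`, differs from compound 2 only by fluoro in place of hydrogen on an aromatic carbon, set ortho to a large group and meta to a carboxy group. For the measured compounds named here, no measured step covers such a change; the one known step concerns the carboxy group itself and says nothing about fluoro in place of hydrogen on an aromatic carbon. With nothing to point either way, compound 3 is expected to stay close to compound 2, with a step of a 1.1-fold higher number from compound 2 to compound 3 (0.06 log units; within the scatter) that need not exceed the scatter. The estimate for compound 3 in this assay is 80 ng.h/mL, within 30 ng.h/mL to 250 ng.h/mL.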

Compound 3, area under the concentration-time curve: 83 ng.h/mL
For compound 3 the middle estimate is 1.0-fold (0.02 log units) below the measured one, and the stated range covers the measured number.
By their numbers in this assay, from the lowest: compounds 2 and 3 (each within the scatter of the next); then compound 1.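

For the compounds shown here, the first reading at this position, ortho to a large group and meta to a carboxy group, shows a 1.2-fold higher number from compound 2 to compound 3 (0.07 log units; within the scatter) in this assay when fluoro replaces hydrogen, so this single fluorine does not shift the number beyond the scatter. Placing 4-carboxy-2-fluorophenyl where compound 1 carries 4-(1-carboxycyclopropyl)phenyl gives a 3.9-fold lower number from compound 1 to compound 3 (0.59 log units; beyond the scatter), so the fluoro compound remains well short of compound 1. Nothing available here explains why the fluoro group makes so little difference.

On these data alone, whether a chlorine atom or a methyl group at this same position would behave like fluoro remains open. So does the effect of the same fluoro in compound 1, where the 1-carboxycyclopropyl group takes the place of the plain carboxy group.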